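Nitro to chloro exchange on the shared core

This account rests on a few compounds, and the source may have more. Where it says the series, first, only, none or still open, it means among the compounds named here.

Measured so far in a functional assay on MCF7 cells (Homo sapiens) for cytotoxicity, read by MTT assay, with a stated time of 48 h; a lower number here means a stronger inhibitor, a higher number a weaker inhibitor:
compound 1 `CCn1c(/C=C2/C(=O)Nc3ccc(C)cc32)nc2ccccc21` gives > 50000 nM
compound 2 `CC(C)n1c(/C=C2/C(=O)Nc3ccc(Cl)cc32)nc2ccccc21` gives 24000 nM
compound 3 `CCn1c(/C=C2/C(=O)Nc3ccc([N+](=O)[O-])cc32)nc2ccccc21` gives > 50000 nM

Compound 3 stands at a limit of this assay, not at a number; its value is > 50000 nM. The same limit holds for compound 1, which gives > 50000 nM in this assay, so two of the three values shown sit at the limit of > 50000 nM in this assay, at which 2 of the 3 values shown sit, and only compound 2 returns a number. Among the compounds with values here, the single step that can be drawn between measured compounds, a step that the two limits leave unreadable from compound 1 to compound 3, is itself unreadable, as both ends rest on the limit.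

Compound 4 `CCn1c(/C=C2/C(=O)Nc3ccc(Cl)cc32)nc2ccccc21` follows from compound 3 by the change (chloro in place of nitro on an aromatic carbon). Within the data shown here, no measured step carries this exact change, so the expectation rests on what the values themselves show: compound 2, the only measured compound bearing chloro at this place, gives 24000 nM, while compound 4 carries ethyl rather than isopropyl on the other side of the core. The size of the step cannot be read from compound 3, whose value is a limit.

Compound 4 is therefore expected near 30000 nM, in the range 12000 nM to 70000 nM, with a real chance that this assay again returns only a limit. The step this estimate means, an at least 1.6-fold lower number from compound 3 to compound 4 (0.22 log units; that floor lies within the scatter), is expected to run toward stronger inhibition but cannot be sized from the limit at compound 3.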

Compound 4, half-maximal inhibitory concentration: > 50000 nM
Compound 4: a limit, no number; the forecaster's own chance of this, stated with the estimate: 40%; at least 1.6-fold (0.22 log units) between middle value and limit.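

In this assay, chloro on this aromatic carbon does not return a number by itself: with ethyl on the other side of the shared core, compound 4 gives a limit, > 50000 nM. Within the data shown here, the one readable step lies at the other place, on the saturated chain carbon bound to the aromatic nitrogen: hydrogen in place of methyl there gives an at least 2.0-fold higher number from compound 2 to compound 4 (0.31 log units; beyond the scatter), so the only number goes with isopropyl and not with chloro alone. The steps to compound 4 from compound 1 and from compound 3 cannot be read, and methyl, nitro and chloro on this aromatic carbon stay unranked with ethyl on the core, because both ends of each step rest on the same limit: the limit of > 50000 nM in this assay, at which 3 of the 4 values shown sit.

Open is whether isopropyl also returns a number alongside methyl or nitro on this aromatic carbon, a pairing absent from the compounds shown. Also open, from the compounds shown here alone, is whether a longer chain such as butyl at the isopropyl place, or an amine in place of chloro on the aromatic carbon, gives a number in this assay.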